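The source may hold more compounds than are shown below. What is called first, only, known or untested is meant among the compounds shown, and "the series" means these compounds.

Working notes on the series. In an assay on membranes from brain for binding affinity to Lysophosphatidylserine lipase ABHD12 (Mus musculus), read by fluorescence, with a stated time of 20 min, tested at 2 uM (on this read-out lower numbers stand for a weaker effect and higher numbers for a stronger effect at the one concentration tested), compound 1 `O=C(Nc1cccnc1)NC1CCN(c2ncc(C(F)(F)F)cc2Cl)CC1` gives 1%, compound 2 `FC(F)(F)c1cnc(N2CCC(NC(=S)Nc3cccnc3)CC2)c(Cl)c1` gives 89% and compound 3 `FC(F)(F)c1cnc(N2CCC(NC(=S)N3CCCc4ccccc43)CC2)c(Cl)c1` gives 0%. Compound 3 thus stands lowest of the three, within the scatter of compound 1 and far beneath compound 2. The thiocarbonyl is shared by compounds 2 and 3, so the step of a number 89 percentage points lower from compound 2 to compound 3 (beyond the scatter) rests on the change at the thiocarbonyl carbon alone; a number 88 percentage points higher from compound 1 to compound 2 (beyond the scatter) bears only indirectly, showing the thiocarbonyl itself is needed. Compound 4 `FC(F)(F)c1cnc(N2CCC(NC(=S)Nc3ccccc3)CC2)c(Cl)c1` differs from compound 3 by anilino in place of 1,2,3,4-tetrahydroquinolin-1-yl on a thiocarbonyl carbon, bringing back an arylamino with one hydrogen-bond donor, as in compound 2, though anilino rather than (pyridin-3-yl)amino. A large upward step a number 75 percentage points higher from compound 3 to compound 4 (beyond the scatter) is expected because a number 89 percentage points lower from compound 2 to compound 3 (beyond the scatter) describes the reverse kind of swap. Compound 4 is estimated at 75%, with a range from 40% to 95%.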

Compound 4, a percentage reported as inhibition, at one concentration (the size of the read-out at that concentration, not a potency): 66%
Compound 4: middle estimate off by 9 percentage points, on the high side; low and high end bracket the measured number.
By their numbers in this assay, from the lowest: compounds 3 and 1 (each within the scatter of the next); then compound 4; then compound 2.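

The step of a number 66 percentage points higher from compound 3 to compound 4 (beyond the scatter) shows that on the thiocarbonyl carbon, anilino recovers much of the inhibition lost with 1,2,3,4-tetrahydroquinolin-1-yl, so a ring of carbon only can serve here, although the step of a number 23 percentage points lower from compound 2 to compound 4 (beyond the scatter) shows a modest cost for phenyl in place of pyridin-3-yl. The step of a number 65 percentage points higher from compound 1 to compound 4 (beyond the scatter) combines the thiocarbonyl and ring changes, so it cannot be divided between them. No evidence here accounts for these differences. As far as these compounds go, it remains open whether an N-methylanilino group, without the closed ring, also loses inhibition, and how benzylamino or cyclohexylamino would compare with anilino.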